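The source may hold more compounds than are shown below. What is called first, only, known or untested is meant among the compounds shown, and "the series" means these compounds.

Measured compounds:
- compound 1, `Cc1nc(C)c(C(=O)Oc2ccc(/C=C/C(=O)O)cc2O)nc1C`: 285%
- compound 2, `COc1ccc(/C=C/C(=O)O)c(OC(=O)c2nc(C)c(C)nc2C)c1`: 31.6%

Among the measured compounds shown here, in a functional assay on EA.hy 926 cells (Homo sapiens) for cytotoxicity, read by MTT assay, with stated times of 24 h and 12 h, tested at 50 uM (on this read-out higher numbers stand for a stronger effect at the one concentration tested and lower numbers for a weaker effect), compound 1 gives 285% and stands highest of the two numbers known; its nearest neighbour, compound 2, gives 31.6% in this assay, a gap that lies beyond the usual scatter. For the measured compounds named here, compound 1 and compound 2 differ in more than one place, so no single step between measured compounds can be read from them.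

Compound 3, `CCOC(=O)/C=C/c1ccc(OC(=O)c2nc(C)c(C)nc2C)c(O)c1`, has not yet been tested in this assay. It differs from compound 1 by ethyl in place of hydrogen on an oxygen next to a carbonyl group. Going by the values given here, no measured pair shows what such a change does in this assay, so the size of the step from compound 1 to compound 3 cannot be taken from the data; with only the high number of compound 1 as a reference, he expects the step of a number 95 percentage points lower from compound 1 to compound 3 (beyond the scatter) to run downward, though a result within the scatter of compound 1 remains possible. For compound 3 he therefore estimates 190% in this assay, with a range from 60% to 320%.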

Compound 3, a percentage reported as activity, at one concentration (the size of the read-out at that concentration, not a potency): 211%
For compound 3 the middle estimate is 21 percentage points below the measured one; low and high end bracket the measured number.
By their numbers in this assay, from the lowest: compound 2; then compound 3; then compound 1.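

In this assay, among the compounds shown here, the change from carboxy to ethoxycarbonyl gives the first step that can be read at all, and it is large: a number 74 percentage points lower from compound 1 to compound 3 (beyond the scatter). For the compounds shown here, it shows that the read-out responds to what sits on this oxygen next to a carbonyl group, which the earlier compounds could not show, since they offered no single change to read. It also shows that the number does not collapse when ethyl takes the place of hydrogen, as compound 3 still gives 211%, and nothing available here accounts for the size or direction of this step.

The compounds shown leave open whether this step belongs to ethyl in particular or to any loss of the hydrogen, since a methyl ester, a longer chain such as a butyl ester, or a primary amide at the same place might each give a different number. They also leave open whether ethyl in place of this hydrogen would move the number in the same direction, and by a similar size, on compound 2.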